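Swapping the sulfonyl ring of compound 2

The source may hold more compounds than are shown below. What is called first, only, known or untested is meant among the compounds shown, and "the series" means these compounds.

Measured in an ADME assay on Vero cells (Chlorocebus sabaeus) for cytotoxicity, read by MTT assay; on this read-out higher numbers stand for lower toxicity in this test and lower numbers for higher toxicity in this test:
- compound 1 `COC(=O)c1ccccc1-n1nc(C(F)(F)F)cc1C(=O)Nc1ccc(S(=O)(=O)N2CCCC2)cc1`: "not determined" (no result reported)
- compound 2 `Cn1nc(C(F)(F)F)cc1C(=O)Nc1ccc(S(=O)(=O)N2CCCCCCC2)cc1`: 16000 nM

Among the measured compounds shown here, compound 2 holds the only number available, so it cannot yet be ranked against anything. Compound 1 has no result that could serve as a comparison.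

The next compound to be tested is compound 3 `Cn1nc(C(F)(F)F)cc1C(=O)Nc1ccc(S(=O)(=O)n2ccc3ccccc32)cc1`, which keeps the rest of compound 2 and changes one group: a group of 9 heavy atoms (8 carbon, 1 nitrogen; one five-membered aromatic ring with 1 hetero atom, one six-membered aromatic ring of carbon only) in place of a group of 8 heavy atoms (7 carbon, 1 nitrogen; one eight-membered non-aromatic ring with 1 hetero atom), on a sulfonyl sulfur. In words, a 1H-indol-1-yl group replaces the eight-membered non-aromatic ring on a sulfonyl sulfur.

For the measured compounds named here, no measured step shows what such a change does in this assay, so the expectation rests on compound 2 at 16000 nM alone. No shift beyond the usual scatter and no firm direction is expected, and the expected step is a 1.3-fold higher number from compound 2 to compound 3 (0.10 log units; within the scatter). The estimate for compound 3 is 20000 nM, with an expected range from 6000 nM to 70000 nM.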

Compound 3, half-maximal cytotoxic concentration: 13000 nM
Compound 3: middle estimate off by 1.5-fold (0.19 log units), on the high side; measured number inside the range.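

Among the compounds shown here, this is the first measured step at the sulfonyl sulfur: in this assay, 1H-indol-1-yl in place of the eight-membered non-aromatic ring gives a 1.2-fold lower number from compound 2 to compound 3 (0.09 log units; within the scatter). On this read-out, the two compounds cannot be told apart, so an aromatic group of two fused rings and a single non-aromatic ring are both compatible with a reading of this size at this position. No supporting measurement bears on why the two groups read alike.

On these data alone, it remains open whether an open-chain diethylamino group or a group carrying a carboxylic acid on the sulfonyl sulfur would shift the number beyond the scatter. Also open, as far as these compounds go, is whether a carboxylic acid in place of the trifluoromethyl group on the shared core would change the reading in this assay.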